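The source may report more compounds than this note shows. Statements on the series, on what has been measured and on what is new or still open speak of the compounds shown alone.

Measured compounds:
Compound 1 `C=C(c1ccc(Cl)c(Cl)c1Cl)C1COC2(CCCC2)OO1` gives 11500 nM in a functional assay on BEAS-2B cells (Homo sapiens) for inhibition, read by MTT assay, with a stated time of 72 h; on this read-out lower numbers stand for stronger inhibition and higher numbers for weaker inhibition.
Compound 3 `C=C(c1ccc(Cl)c(Cl)c1Cl)C1COC(C)(C)OO1` gives 10200 nM in this assay.
For compound 2 `C=C(c1ccc(Cl)c(Cl)c1)C1COC(C)(C)OO1` this assay reports only a limit, > 100000 nM.

Compound 1 and compound 3 give numbers within the usual scatter of each other; how their two cores differ is not broken down here. From compound 3 to compound 2 the change is hydrogen in place of chloro on an aromatic carbon, and it brings an at least 9.8-fold higher number from compound 3 to compound 2 (0.99 log units; beyond the scatter). The value of compound 2 sits at the limit (the limit of > 100000 nM in this assay, at which 1 of the 3 values shown sits), so the true size of that step is not bounded from above.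

Compound 4 `C=C(c1ccc(Cl)c(Cl)c1)C1COC2(CCCC2)OO1` is not yet measured. It comes from compound 1 by hydrogen in place of chloro on an aromatic carbon, the same change as from compound 3 to compound 2. The step is expected to be a 10-fold higher number from compound 1 to compound 4 (1.02 log units; beyond the scatter), resting on the step from compound 3 to compound 2, an at least 9.8-fold higher number from compound 3 to compound 2 (0.99 log units; beyond the scatter), which started from a number close to that of compound 1. Compound 4 is estimated at 120000 nM, with the range 40000 nM to 400000 nM, and a reading that is only a limit is considered likely.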

Compound 4, half-maximal inhibitory concentration: 50900 nM
For compound 4 the middle estimate is 2.4-fold (0.37 log units) above the measured one, and the stated range covers the measured number.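

On the core of compound 1, hydrogen in place of chloro on an aromatic carbon weakens inhibition in this assay, with a 4.4-fold higher number from compound 1 to compound 4 (0.65 log units; beyond the scatter), so the direction of the change carries over to a second core. This rests on two matched pairs only, and it does not show that the size of the step carries over: the same change on two cores in this assay, an at least 9.8-fold higher number (0.99 log units; beyond the scatter) from compound 3 to compound 2 and a 4.4-fold higher number (0.65 log units; beyond the scatter) from compound 1 to compound 4; the limit leaves it open whether they differ
Compound 2 is the compound that stands at a limit, which is not a number: the limit of > 100000 nM in this assay, at which 1 of the 4 values shown sits.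

Among the compounds shown, this place on the aromatic ring holds only chloro or hydrogen, so the effect of a fluoro, a methoxy or an amine there remains open. Also open, on these data alone, is whether the direction of the step holds on any core beyond these two.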